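Aryl piperazine dithiocarbamates on a diaminoquinazoline core

The source may hold more compounds than are shown below. What is called first, only, known or untested is meant among the compounds shown, and "the series" means these compounds.

Two compounds share a core and differ only in the aryl group on the piperazine. Compound 1 `COc1ccc(N2CCN(C(=S)SCc3ccc4nc(N)nc(N)c4c3)CC2)cc1` and compound 2 `Nc1nc(N)c2cc(CSC(=S)N3CCN(c4ccc(Cl)cc4)CC3)ccc2n1` were examined in a functional assay on MCF7 cells (Homo sapiens) for antiproliferative activity, read by MTT assay, with a stated time of 72 h; a lower number here means a stronger inhibitor, a higher number a weaker inhibitor. Compound 1 gives 1580 nM, while compound 2 gives 4880 nM, the higher of the two numbers; the change was a 3.1-fold higher number from compound 1 to compound 2 (0.49 log units; beyond the scatter). Compound 3 `Nc1nc(N)c2cc(CSC(=S)N3CCN(c4ccccn4)CC3)ccc2n1` is the next member: pyridin-2-yl in place of 4-chlorophenyl on an amine nitrogen in a ring. Within the data shown here, no measured step exchanges an aryl ring for a pyridine, so the only guide is the single aryl substituent step from compound 1 to compound 2, which was modest. A change of similar size is therefore expected, with no firm direction, so the estimate is a step of a 1.5-fold lower number from compound 2 to compound 3 (0.18 log units; within the scatter). Compound 3 is thus expected to give about 3200 nM, plausibly between 1000 nM and 10000 nM.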

Compound 3, half-maximal inhibitory concentration: 5110 nM
Compound 3: middle estimate off by 1.6-fold (0.20 log units), on the low side, and the stated range covers the measured number.
By their numbers in this assay, from the lowest: compound 1; then compounds 2 and 3 (each within the scatter of the next).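

In this assay, pyridin-2-yl in place of 4-chlorophenyl on the amine nitrogen in the ring gives a 1.0-fold higher number from compound 2 to compound 3 (0.02 log units; within the scatter), so at this position a ring with one hetero atom and one hydrogen-bond acceptor reads the same, within the scatter, as a carbon-only ring bearing chlorine. Pyridin-2-yl in place of 4-methoxyphenyl gives a 3.2-fold higher number from compound 1 to compound 3 (0.51 log units; beyond the scatter), which leaves compound 1 with the lowest number of the three, set apart from both other aryl groups. Nothing available explains these numbers.

On these data alone, whether a 4-ethoxyphenyl or 4-dimethylaminophenyl group on that nitrogen would read like compound 1, and how an unsubstituted phenyl would read, stays open. Also open, as far as these compounds go, is whether pyridin-3-yl or pyridin-4-yl would read like compound 3.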